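Swapping a sulfanyl side group for chloro in compound 4

The compounds below may be only part of what the source reports. "The series", "measured", "known", "first", "only" and "open" are said of these compounds alone.

compound 1 `C=C1C2=C(C(=O)N1OC)[C@H](OC(=O)CSc1nc3ccccc3o1)[C@@](C)(O)[C@H](CCCCC)O2` gives 5100 nM
compound 2 `C=C1C2=C(C(=O)N1OC)[C@H](OC(=O)CSc1nc3ccccc3s1)[C@@](C)(O)[C@H](CCCCC)O2` gives 2000 nM
compound 3 `C=C1C2=C(C(=O)N1OC)[C@H](OC(=O)CSc1nc3ccccc3[nH]1)[C@@](C)(O)[C@H](CCCCC)O2` gives 4300 nM

All three numbers come from a functional assay on RPMI-8226 cells (Homo sapiens) for cytotoxicity, read by MTT assay, with a stated time of 72 h (on this read-out lower numbers stand for stronger inhibition and higher numbers for weaker inhibition), and compound 3 stands at 4300 nM in the upper part of that small set. Two measured steps place it: there is a 1.2-fold lower number from compound 1 to compound 3 (0.07 log units; within the scatter) and there is a 2.2-fold higher number from compound 2 to compound 3 (0.33 log units; beyond the scatter) to complete the picture.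

Compound 4 `C=C1C2=C(C(=O)N1OC)[C@H](OC(=O)CCl)[C@@](C)(O)[C@H](CCCCC)O2` keeps the shared core and differs in one place: chloro in place of (1H-benzimidazol-2-yl)sulfanyl on a saturated chain carbon bound to a carbonyl carbon.

The measured steps only exchange one ring group on the sulfur for another, and the largest of them is a 2.6-fold lower number from compound 1 to compound 2 (0.41 log units; beyond the scatter) so they are a weak guide. None of them removes the sulfur and its rings, and they show no direction for such a change. In this assay no step beyond the scatter is therefore expected, though with much uncertainty. The estimate means a 1.4-fold lower number from compound 3 to compound 4 (0.16 log units; within the scatter) as an expected step only. For compound 4 the estimated value is 3000 nM within an expected range of 700 nM to 12000 nM as a first guess.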

Compound 4, half-maximal inhibitory concentration: 9700 nM
For compound 4 the middle estimate is 3.2-fold (0.51 log units) below the measured one; low and high end bracket the measured number.
By their numbers in this assay, from the lowest: compound 2; then compounds 3, 1 and 4 (each within the scatter of the next, the first and the last beyond it).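

Replacing the whole sulfur-and-ring unit with a single chloro on a saturated chain carbon bound to a carbonyl carbon leaves compound 4 with a measurable number in this assay, so the ring groups are not required for some activity here. Their loss matters to a different degree depending on which ring leaves: there is a 4.9-fold higher number from compound 2 to compound 4 (0.69 log units; beyond the scatter) and a 2.3-fold higher number from compound 3 to compound 4 (0.35 log units; beyond the scatter), both modest, whereas a 1.9-fold higher number from compound 1 to compound 4 (0.28 log units; within the scatter) does not separate the two compounds. No measurement shown explains this difference between the ring groups.

As far as these compounds go, it remains open whether the sulfur or the ring accounts for the lower numbers of compound 2 and compound 3, a question that a simple methylsulfanyl group on the same carbon could help settle. From the compounds shown here alone, how an amine or a hydroxyl group would behave there also remains open.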